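Saturating the ring at the side chain of compound 3

This account rests on a few compounds, and the source may have more. Where it says the series, first, only, none or still open, it means among the compounds named here.

Compound 1 `CC1CCC(C[C@H](NC(=O)c2ccco2)C(=O)N[C@H]2CC[C@@H](C)N(S(=O)(=O)c3ccccn3)CC2=O)CC1` gives 0.5 nM in an assay on isolated protein for inhibition of cathepsin S (Homo sapiens), read by fluorescence; a higher number here means a weaker inhibitor, a lower number a stronger inhibitor. Compound 2 `C[C@@H]1CC[C@H](NC(=O)[C@H](CC2CCCCCC2)NC(=O)c2ccco2)C(=O)CN1S(=O)(=O)c1ccccn1` reaches only a limit of this assay, < 0.4 nM, so its number is not known. Compound 3 `C[C@@H]1CC[C@H](NC(=O)[C@H](CC2=CCCC2)NC(=O)c2ccco2)C(=O)CN1S(=O)(=O)c1ccccn1` gives 4.9 nM, the highest number among the three and hence the weakest inhibitor shown. Compound 4 `C[C@@H]1CC[C@H](NC(=O)[C@H](CCC2CCCC2)NC(=O)c2ccco2)C(=O)CN1S(=O)(=O)c1ccccn1` differs from compound 3 by cyclopentylmethyl in place of cyclopent-1-en-1-yl on a saturated chain carbon, two bonds along the chain from an amide-type nitrogen and a carbonyl carbon. The step of a 9.8-fold higher number from compound 1 to compound 3 (0.99 log units; beyond the scatter) and the step of an at least 12-fold higher number from compound 2 to compound 3 (1.08 log units; beyond the scatter) both show that replacing a saturated ring at this position with cyclopent-1-en-1-yl weakens inhibition; compound 4 reverses that, restoring a saturated ring. He therefore expects the number for compound 4 to drop, with a 4.9-fold lower number from compound 3 to compound 4 (0.69 log units; beyond the scatter). His estimate for compound 4 is 1 nM, within 0.4 nM to 3 nM.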

Compound 4, half-maximal inhibitory concentration: 1.9 nM
Compound 4: middle estimate off by 1.9-fold (0.28 log units), on the low side; the measured number falls inside the stated range.
By their numbers in this assay, from the lowest: compound 1; then compound 4; then compound 3. At a limit, below all of these: compound 2.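

Moving to cyclopentylmethyl gives a 2.6-fold lower number from compound 3 to compound 4 (0.41 log units; beyond the scatter), so a saturated five-membered ring on this longer chain recovers part of the potency but not all of it, with a 3.8-fold higher number from compound 1 to compound 4 (0.58 log units; beyond the scatter) and an at least 4.7-fold higher number from compound 2 to compound 4 (0.67 log units; beyond the scatter). The last of these steps is only a floor, since compound 2 stands at a limit: the limit of < 0.4 nM in this assay, at which 1 of the 4 values shown sits.

This one change both removes the double bond and lengthens the group from (cyclopent-1-en-1-yl)methyl to 2-cyclopentylethyl, so the compounds shown leave the two effects unseparated. Plain cyclopentylmethyl on the chain of compound 3, as the saturated match for its ring, and 2-cyclohexylethyl remain open.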